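A few compounds are considered here, and "the series" means these few. Any claim that something is new, unique, unknown or untested is made for them only; others in the source may bear on it.

In a functional assay on DLD-1 cells (Homo sapiens) for antiproliferative activity, read by CellTiter-Glo, with a stated time of 72 h (on this read-out higher numbers stand for weaker inhibition and lower numbers for stronger inhibition), compound 1 `CC1CCN(C2CCN(S(=O)(=O)c3cccc(C(F)(F)F)c3)CC2)CC1` gives only a limit of the assay, > 5000 nM. Compound 2 `CC1CCN(C2CCN(S(=O)(=O)c3cccc(Cl)c3)CC2)CC1` likewise yields only a limit, > 5000 nM. Compound 3 `CC1CCN(C2CCN(S(=O)(=O)c3cccc(-c4ccccc4C(F)(F)F)c3)CC2)CC1` gives 10 nM. Two of the three values shown thus sit at the limit of > 5000 nM in this assay, at which 2 of the 3 values shown sit, so the step that the two limits leave unreadable from compound 1 to compound 2, whereas the step of an at least 500-fold lower number from compound 1 to compound 3 (2.69 log units; beyond the scatter) and the step of an at least 500-fold lower number from compound 2 to compound 3 (2.69 log units; beyond the scatter) are the only ones with a readable size. Compound 4 `CC1CCN(C2CCN(S(=O)(=O)c3ccc([N+](=O)[O-])c(C(F)(F)F)c3)CC2)CC1` differs from compound 1 by nitro in place of hydrogen on an aromatic carbon. Among the measured compounds shown here, none of the measured steps adds a nitro group. The two large steps both bring in a 2-(trifluoromethyl)phenyl ring in place of a small group, whereas the nitro group of compound 4 brings no ring and leaves the trifluoromethyl group of compound 1 in place. For compound 4 in this assay no change beyond the scatter is therefore expected, a step that the limit leaves unreadable from compound 1 to compound 4. Compound 4 is estimated at 8000 nM, between 2000 nM and 30000 nM, most likely reported again only as a limit.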

Compound 4, half-maximal inhibitory concentration: 56 nM
The estimate for compound 4 lay 140-fold (2.15 log units) above the measured number; measured number below the stated range.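

In this assay, adding nitro on the aromatic carbon ortho to a trifluoromethyl group and para to a large group gives an at least 89-fold lower number from compound 1 to compound 4 (1.95 log units; beyond the scatter). The earlier large steps each brought in a 2-(trifluoromethyl)phenyl ring, whereas this change brings no ring and leaves the trifluoromethyl group of compound 1 in place, so a large step here does not require that ring. Compound 1 stands only at a limit of the assay, so this step has a floor but no known upper end: the limit of > 5000 nM in this assay, at which 2 of the 4 values shown sit.

The compounds shown leave open whether this carbon responds to nitro in particular or to other added groups, as an amine or a methoxy group at this carbon is not among them. Also open, from the compounds shown here alone, is what nitro at this carbon would do in a compound carrying the 2-(trifluoromethyl)phenyl ring of compound 3.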